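Adding Chloro to Compound 2: An Expected Shift

The source may report more compounds than this note shows. Statements on the series, on what has been measured and on what is new or still open speak of the compounds shown alone.

Compound 1 `COc1cc(/C=C2\C(=O)Nc3ccc(Cl)cc32)ccc1OCCCN1CC(C)OC(C)C1` and compound 2 `COc1cc(/C=C2\C(=O)Nc3ccccc32)ccc1OCCCN1CCN(c2ccccn2)CC1` share a core and were both tested in a functional assay on BT-549 cells (Homo sapiens) for cytotoxicity, read by MTT assay, with a stated time of 48 h; on this read-out lower numbers stand for stronger inhibition and higher numbers for weaker inhibition. Compound 1 gives 2770 nM. Compound 2 reaches only a limit of this assay, > 20000 nM, which is not a number. Compound 2 thus stands at the limit of > 20000 nM in this assay, at which 1 of the 2 values shown sits. Compound 3 `COc1cc(/C=C2\C(=O)Nc3ccc(Cl)cc32)ccc1OCCCN1CCN(c2ccccn2)CC1`, not yet measured, differs from compound 2 in one place: chloro in place of hydrogen on an aromatic carbon. Compound 1 also carries this chloro but differs elsewhere, so the change cannot be read directly. Compound 3 is expected to show a step of an at least 1.6-fold lower number from compound 2 to compound 3 (0.22 log units; that floor lies within the scatter). Compound 3 is estimated at 12000 nM, in a range from 3000 nM to 30000 nM.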

Compound 3, half-maximal inhibitory concentration: > 20000 nM
Compound 3: only a limit was reported (the forecaster's own chance of this, stated with the estimate: 45%); middle value at least 1.6-fold (0.22 log units) away from the limit.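

In this assay compound 3 gives only a limit, as compound 2 does, so the effect of the chloro on this aromatic carbon cannot be read: the limit of > 20000 nM in this assay, at which 2 of the 3 values shown sit.

With the chloro held constant, the group on the chain does make a readable difference: 4-(pyridin-2-yl)piperazin-1-yl in place of 2,6-dimethylmorpholin-4-yl gives an at least 7.2-fold higher number from compound 1 to compound 3 (0.85 log units; beyond the scatter), which means weaker inhibition.

As far as these compounds go, what the chloro contributes alongside 2,6-dimethylmorpholin-4-yl stays open. So does whether a fluoro on this carbon, or a piperidine on the chain, would give a readable number.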